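This account rests on a few compounds, and the source may have more. Where it says the series, first, only, none or still open, it means among the compounds named here.

In a functional assay on U-251 cells (Homo sapiens) for cytotoxicity (on this read-out lower numbers stand for stronger inhibition of growth and higher numbers for weaker inhibition of growth), compound 3 `CSc1ccc(C2=C(c3ccc(O)cc3)C(=O)N3CCCC3C2)cc1` gives only a limit, > 100000 nM, and not a number. That leaves it at the weak end of the series, with the limit of > 100000 nM in this assay, at which 1 of the 3 values shown sits. Compound 1 `COc1ccc(C2=C(c3ccc(SC)cc3)CC3CCCN3C2=O)cc1O` reads 5000 nM, and compound 2 `COc1ccc(C2=C(c3ccc(SC)cc3)CC3CCCN3C2=O)cc1C` reads 90 nM. Compound 4 `CSc1ccc(C2=C(c3ccc(C(F)(F)F)cc3)C(=O)N3CCCC3C2)cc1` keeps the core of compound 3 but has trifluoromethyl in place of hydroxy on an aromatic carbon, para to a large group: trifluoromethyl in place of hydroxy on an aromatic carbon. The closest measured change is a 56-fold lower number from compound 1 to compound 2 (1.74 log units; beyond the scatter), also a large step, where methyl replaced hydroxy on an aromatic carbon, although the entering group differs there. The steps of an at least 20-fold higher number from compound 1 to compound 3 (1.30 log units; beyond the scatter) and an at least 1100-fold higher number from compound 2 to compound 3 (3.04 log units; beyond the scatter) are also large, and both end at the 4-hydroxyphenyl of compound 3. On these steps, removing the hydroxy is expected to give a large move towards a lower number in this assay, though probably not as far as compound 2 at 90 nM. The expected change is an at least 33-fold lower number from compound 3 to compound 4 (1.52 log units; beyond the scatter). For compound 4 the estimated value is 3000 nM, with an expected range from 300 nM to 30000 nM.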

Compound 4, concentration for 50% growth inhibition: 800 nM
Compound 4: middle estimate off by 3.8-fold (0.57 log units), on the high side; low and high end bracket the measured number.
By their numbers in this assay, from the lowest: compound 2; then compound 4; then compound 1. At a limit, above all of these: compound 3.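

In this assay, trifluoromethyl in place of hydroxy on an aromatic carbon, para to a large group, gives an at least 120-fold lower number from compound 3 to compound 4 (2.09 log units; beyond the scatter). Among the compounds shown here, until now, replacing a hydroxy had been seen only with methyl as the entering group and at a different place, in a 56-fold lower number from compound 1 to compound 2 (1.74 log units; beyond the scatter), so the lower number now holds for a second place and a second entering group, one that carries no hydrogen-bond donor or acceptor. The true size of the new step remains a bound, because compound 3 gives only a limit and not a number: the limit of > 100000 nM in this assay, at which 1 of the 4 values shown sits.

The compounds shown leave open whether the lower number comes from the hydroxy leaving or from the trifluoromethyl entering. A methyl, an amine or a carboxylic acid at this place would help to separate the two.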